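Dropping a Ring Methyl: What Three Analogues Suggest

The source may hold more compounds than are shown below. What is called first, only, known or untested is meant among the compounds shown, and "the series" means these compounds.

Three close analogues share one core and differ only at two places. Compound 1 `COc1cc2c(Nc3nc4ccc(C(=O)Nc5c(C)cc(C)cc5C)cc4s3)ncnc2cc1OCCCN1CCC(C)CC1` gives 5400 nM in a functional assay on A549 cells (Homo sapiens) for cytotoxicity, read by WST assay, with a stated time of 72 h (on this read-out lower numbers stand for stronger inhibition and higher numbers for weaker inhibition), the lowest of the three numbers, although compound 2 `COc1cc2c(Nc3nc4ccc(C(=O)Nc5c(C)cccc5Cl)cc4s3)ncnc2cc1OCCCN1CCCCC1C` with 6700 nM and compound 3 `COc1cc2c(Nc3nc4ccc(C(=O)Nc5c(C)cccc5Cl)cc4s3)ncnc2cc1OCCCN1CCC(C)CC1` with 9700 nM both lie within the scatter of it. Compound 4 `COc1cc2c(Nc3nc4ccc(C(=O)Nc5c(C)cc(C)cc5C)cc4s3)ncnc2cc1OCCCN1CCCCC1` is not yet measured; it differs from compound 1 by hydrogen in place of methyl on a saturated ring carbon, so that 4-methylpiperidin-1-yl becomes piperidin-1-yl. Among the measured compounds shown here, only one measured step touches that ring: a 1.4-fold higher number from compound 2 to compound 3 (0.16 log units; within the scatter). The other step, a 1.8-fold higher number from compound 1 to compound 3 (0.25 log units; within the scatter), concerns the group on the amide-type nitrogen. Neither moved beyond the scatter, so no step beyond the scatter is expected here. Compound 4 is therefore estimated at 6000 nM, within 2500 nM to 14000 nM, an expected step of a 1.1-fold higher number from compound 1 to compound 4 (0.05 log units; within the scatter).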

Compound 4, half-maximal inhibitory concentration: 10300 nM
Compound 4: the middle estimate sits 1.7-fold (0.23 log units) below what was measured, and the stated range covers the measured number.
By their numbers in this assay, from the lowest: compounds 1, 2, 3 and 4 (each within the scatter of the next).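

Taking the methyl off the saturated ring carbon, three ring bonds from the ring nitrogen, gives a 1.9-fold higher number from compound 1 to compound 4 (0.28 log units; within the scatter) in this assay. This is the first step shown that adds or removes an atom on this ring rather than shifting the methyl, and bare piperidin-1-yl stays within the scatter of 4-methylpiperidin-1-yl. No measurement offered here accounts for this result. From the compounds shown here alone, whether an amino group or a longer chain on that ring carbon would move the number beyond the scatter remains open. So does whether removing the methyl from compound 3 would give a similar step.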